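Coumarin-Free Title: From Amine to Carbamate at One Position

This account rests on a few compounds, and the source may have more. Where it says the series, first, only, none or still open, it means among the compounds named here.

Of the compounds shown here, two of a shared core have been measured in an assay on isolated protein (strain Sprague-Dawley) for inhibition of Amine oxidase [flavin-containing] B (Rattus norvegicus), read by spectrophotometry, with a stated time of 5 min; a higher number here means a weaker inhibitor, a lower number a stronger inhibitor. Compound 1 `CCOc1cc(=O)oc2cc(OCc3cccc(Cl)c3)ccc12` carries an ethoxy group and gives 115 nM. Compound 2 `Nc1cc(=O)oc2cc(OCc3cccc(Cl)c3)ccc12` carries an amino group in its place and gives 47.9 nM. The step of a 2.4-fold lower number from compound 1 to compound 2 (0.38 log units; beyond the scatter) is the only one recorded, and it puts compound 2 at the lowest of the two numbers, with compound 1 as its nearest neighbour.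

Compound 3 `CCOC(=O)Nc1cc(=O)oc2cc(OCc3cccc(Cl)c3)ccc12` is not yet measured. It differs from compound 2 in one place: ethoxycarbonyl in place of hydrogen on a nitrogen on an aromatic ring. Within the data shown here, the only measured step that touches this position is the exchange of ethoxy for amino, a 2.4-fold lower number from compound 1 to compound 2 (0.38 log units; beyond the scatter), which shows that what sits at this position moves the number beyond the scatter. Among the measured compounds shown here, no measured pair shows a substituent attached to the nitrogen itself, so the direction of the new step rests on weaker ground.

Given that the amino group of compound 2 gave the lowest number seen, and that compound 3 covers that group with a larger one, compound 3 is expected to come out as a somewhat weaker inhibitor, with an estimated step of a 3.1-fold higher number from compound 2 to compound 3 (0.50 log units; beyond the scatter). The estimate for compound 3 is 150 nM, in a range from 40 nM to 600 nM.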

Compound 3, half-maximal inhibitory concentration: 589 nM
Beside the measured number, compound 3's estimate is 3.9-fold (0.59 log units) below it; the range from low to high includes it.
By their numbers in this assay, from the lowest: compound 2; then compound 1; then compound 3.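

In this assay, putting ethoxycarbonyl on the nitrogen gives a 12-fold higher number from compound 2 to compound 3 (1.09 log units; beyond the scatter), the largest step among these compounds, so this position does not simply accept a bigger group on the amino nitrogen. The change also compares poorly with the simple ethoxy group on the same aromatic carbon, with a 5.1-fold higher number from compound 1 to compound 3 (0.71 log units; beyond the scatter), which makes compound 3 the weakest inhibitor of the three, with both of its steps beyond the scatter. Together, these steps show that a group at this position can push the number up as well as down, and that the far larger shift comes from changing the nitrogen's substituent, not from the earlier exchange of ethoxy for amino. No accompanying measurement explains why the number rises this far.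

The compounds shown leave open whether any group on that nitrogen would raise the number, or only one like ethoxycarbonyl; a methyl or acetyl group there would help to separate the two cases. They also leave open how the number would respond to a longer chain in place of the ethyl part, or to a carboxylic acid at this position.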